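A few compounds are considered here, and "the series" means these few. Any claim that something is new, unique, unknown or untested is made for them only; others in the source may bear on it.

Measured so far in a functional assay on SF-539 cells (Homo sapiens) for inhibition, read by sulforhodamine B assay, with a stated time of 48 h; on this read-out higher numbers stand for lower toxicity in this test and lower numbers for higher toxicity in this test:
- compound 1 `COc1ccc(-c2cc(/C=C/C(=O)c3ccc(OC)c(OC)c3)[nH]n2)cc1` gives 5380 nM
- compound 2 `COc1cc(-c2cc(/C=C/C(=O)c3ccc(Cl)c(Cl)c3)[nH]n2)cc(OC)c1OC` gives 57800 nM
- compound 3 `COc1ccc(-c2cc(/C=C/C(=O)c3ccc(N)cc3)[nH]n2)cc1` gives 8250 nM

Compound 2 stands at the highest of the three numbers; its gaps to compound 3 and to compound 1 both lie beyond the usual scatter. For the measured compounds named here, no pair differing in a single place has been measured, so no measured step is known.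

Compound 4 `COc1ccc(C(=O)/C=C/c2cc(-c3cc(OC)c(OC)c(OC)c3)n[nH]2)cc1OC` is not yet measured. It differs from compound 2 as follows: 3,4-dimethoxyphenyl in place of 3,4-dichlorophenyl on a carbonyl carbon. Compound 1 likewise carries 3,4-dimethoxyphenyl on a carbonyl carbon and gives 5380 nM, a much lower number than compound 2. On that basis the step of a 7.2-fold lower number from compound 2 to compound 4 (0.86 log units; beyond the scatter) is expected to be a clear drop, beyond the scatter. Compound 4 is estimated at 8000 nM, with a range from 2500 nM to 25000 nM.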

Compound 4, concentration lethal to 50% of the cells: 5310 nM
Estimate against measurement, compound 4: 1.5-fold (0.18 log units) above, within the range that was stated.
By their numbers in this assay, from the lowest: compounds 4, 1 and 3 (each within the scatter of the next); then compound 2.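

In this assay, for the compounds shown here, the exchange of 3,4-dichlorophenyl for 3,4-dimethoxyphenyl on a carbonyl carbon gives an 11-fold lower number from compound 2 to compound 4 (1.04 log units; beyond the scatter) and is the first single-place step. This shows that the group at this position can move the number well beyond the scatter, and the high number of compound 2 goes with its 3,4-dichlorophenyl group. No measurement at hand explains the size of this step.

Open, as far as these compounds go, is whether the chlorines raise the number or the methoxy groups lower it, which an unsubstituted phenyl at this position would separate. Also open, from the compounds shown here alone, is whether the exchange gives a similar step on the core of compound 1.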